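The compounds below may be only part of what the source reports. "The series", "measured", "known", "first", "only" and "open" are said of these compounds alone.

Compound 2, `C/C=C/C=C/C(=O)N[C@H](C(=O)NCCCCCCCCCCCC)[C@@H](C)O`, and compound 1, `CCCCCCCCCCCCNC(=O)[C@@H](NC(=O)/C=C/c1ccccc1)[C@@H](C)O`, share one core and differ only in the acyl group on the amine nitrogen. In a functional assay on SiHa cells (Homo sapiens) for cytotoxicity, read by MTT assay, with a stated time of 48 h (a lower number here means a stronger inhibitor, a higher number a weaker inhibitor), compound 1 gives > 200000 nM, which is a limit of the assay and not a number. In this assay compound 2 gives > 200000 nM, again a limit rather than a measured number. The step that the two limits leave unreadable from compound 1 to compound 2 therefore cannot be read, and compound 2 stands at the same limit as compound 1, with no ordering between them: the limit of > 200000 nM in this assay, at which 2 of the 2 values shown sit.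

Compound 3, `CCCCCCCCCCCCNC(=O)[C@@H](NS(=O)(=O)c1cccs1)[C@@H](C)O`, is reached from compound 2 by (thiophen-2-yl)sulfonyl in place of (penta-1,3-dien-1-yl)carbonyl on an amine nitrogen. Among the measured compounds shown here, no measured step bears on this change, and the only measured step is itself unreadable. There is thus no basis for expecting a step beyond the scatter in either direction in this assay; the expectation is that compound 3 behaves like compound 2 and most likely returns a limit again. On that basis the expected step of a number no higher from compound 2 to compound 3 (the limit leaves the size open) is essentially flat. Compound 3 is estimated at 200000 nM, within a range of 50000 nM to 400000 nM.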

Compound 3, half-maximal inhibitory concentration: 30900 nM
Compound 3: middle estimate off by 6.5-fold (0.81 log units), on the high side; measured number below the stated range.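

Put in place of the acyl groups on the amine nitrogen, (thiophen-2-yl)sulfonyl gives in this assay an at least 6.4-fold lower number from compound 2 to compound 3 (0.81 log units; beyond the scatter), and the same group gives an at least 6.4-fold lower number from compound 1 to compound 3 (0.81 log units; beyond the scatter). Among the compounds shown here, these are the first readable steps at this position, since the one earlier change, between two carbonyl-linked groups, could not be read and so showed no sensitivity of this place to any change. Compound 3 is thus the only compound shown that gives a measured number, while compound 1 and compound 2 remain at a limit, which is not a number: the limit of > 200000 nM in this assay, at which 2 of the 3 values shown sit.

The change swaps the carbonyl for a sulfonyl and the open chain or phenyl-bearing end for a thiophene ring in a single step, so the compounds shown cannot say which part carries the shift; a benzenesulfonyl group or a thiophene-2-carbonyl group on the same amine nitrogen would separate the two. As far as these compounds go, both steps also start from a limit, so their true size stays open, as does whether other sulfonyl groups on this nitrogen, such as methanesulfonyl, would give a measured number at all.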